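The source may report more compounds than this note shows. Statements on the series, on what has been measured and on what is new or still open speak of the compounds shown alone.

Compound 1 `Cc1cc(N[C@H](CCCCN)C(=O)NO)cc(C)c1F`, compound 2 `Cc1cc(CNCCCC[C@@H](Nc2cc(C)c(F)c(C)c2)C(=O)NO)ccc1F` and compound 3 `Cc1cc(N[C@H](CCCCNCc2ccc(C(C)(C)C)cc2)C(=O)NO)cc(C)c1F` have been measured, while compound 4 `Cc1cc(N[C@H](CCCCNCCCc2ccc(F)cc2)C(=O)NO)cc(C)c1F` has not. In a physicochemical assay for lipophilicity, at pH 7.4 (a lower number here means a more polar compound, a higher number a more lipophilic compound), compound 1 gives < 3, which is a limit. Compound 2 gives < 3, also a limit. Compound 3 gives < 3, again a limit. Compound 2 therefore stands at the limit of < 3 in this assay, at which 3 of the 3 values shown sit, without an exact position.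

The change to compound 4 is 2-(4-fluorophenyl)ethyl in place of 4-fluoro-3-methylphenyl on a saturated chain carbon bound to an amine nitrogen. Cut one bond further out, 4-fluoro-3-methylbenzyl becomes 3-(4-fluorophenyl)propyl.

The measured changes that bear on this are a step that the two limits leave unreadable from compound 1 to compound 2 and a step that the two limits leave unreadable from compound 2 to compound 3, so neither offers a size to carry over. The expected change, in neither direction beyond the usual scatter, is a step that the limit leaves unreadable from compound 2 to compound 4. Compound 4 is estimated at 2, with an expected range from 1 to 3.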

Compound 4, distribution coefficient: < 3
Compound 4 ended at the assay's limit; the forecaster's own chance of this, stated with the estimate: 90%; the middle value is on the limit's open side.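

In this assay compound 4 gives < 3, a limit, so no step to it from compound 1, compound 2 or compound 3 can be read: the limit of < 3 in this assay, at which 4 of the 4 values shown sit.

The compounds shown leave open where each of these four actually lies in this assay, and whether the changes among them shift it at all.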